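A few compounds are considered here, and "the series" means these few. Any claim that something is new, unique, unknown or untested is made for them only; others in the source may bear on it.

Within the data shown here, compound 1 `ClCc1cccc(Cn2cnc3ncnc(Cl)c32)c1` gives 2880 nM in a functional assay on T47D cells (Homo sapiens) for cytotoxicity, read by sulforhodamine B assay, with a stated time of 48 h (a higher number here means that more compound is tolerated, a lower number that less compound is tolerated), and stands as the only number so far. Compound 2 `ClCc1ccc(Cn2cnc3c(Cl)nc(Cl)nc32)cc1` returns only a limit in this assay, > 100000 nM. Compound 3 `ClCc1cccc(Cn2cnc3nc(Cl)nc(Cl)c32)c1` awaits measurement and differs from compound 1 by chloro in place of hydrogen on an aromatic carbon. Among the measured compounds shown here, no measured step of this kind exists in the set, so direction rests on the two values shown. The expected step in this assay is a 5.2-fold higher number from compound 1 to compound 3 (0.72 log units; beyond the scatter), toward more tolerated compound. Compound 3 is estimated at 15000 nM, within 4000 nM to 80000 nM.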

Compound 3, concentration lethal to 50% of the cells: > 100000 nM
Compound 3: a limit, no number (the forecaster's own chance of this, stated with the estimate: 25%); middle value at least 6.6-fold (0.82 log units) away from the limit.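

In this assay, among these compounds, chloro in place of hydrogen on an aromatic carbon between two ring nitrogen atoms gives an at least 34-fold higher number from compound 1 to compound 3 (1.54 log units; beyond the scatter), the first reading of any change at this position. On the core of compound 1, this single added chloro is enough to lose the measurable cytotoxicity. Compound 3 gives a limit and not a number, so the step sets only a lower bound on the change: the limit of > 100000 nM in this assay, at which 2 of the 3 values shown sit.

From the compounds shown here alone, whether an amine or a methoxy group at this position would keep the cytotoxicity of compound 1 remains open.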